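Swapping the Group on the Ring Nitrogen

A few compounds are considered here, and "the series" means these few. Any claim that something is new, unique, unknown or untested is made for them only; others in the source may bear on it.

Measured compounds:
compound 1, `Nc1ccccc1NC(=O)c1ccc(CSC(=S)N2CCN(c3cccnc3)CC2)cc1`: 76.9%
compound 2, `Nc1ccccc1NC(=O)c1ccc(CSC(=S)N2CCN(c3ncccn3)CC2)cc1`: 64.8%

In a functional assay on MGC-803 cells (Homo sapiens) for antiproliferative activity, read by CCK-8 assay, with a stated time of 72 h, tested at 8 uM (on this read-out lower numbers stand for a weaker effect and higher numbers for a stronger effect at the one concentration tested), compound 1 gives 76.9%, and in this assay compound 2 gives 64.8%. Among the measured compounds shown here, compound 2 therefore stands lowest of the two numbers measured so far; the only step between them, a number 12.1 percentage points lower from compound 1 to compound 2 (beyond the scatter), is the sole change measured at this position.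

Compound 3, `Nc1ccccc1NC(=O)c1ccc(CSC(=S)N2CCN(Cc3ccccc3)CC2)cc1`, has not yet been tested. Its change from compound 2 is benzyl in place of pyrimidin-2-yl on an amine nitrogen in a ring. For the measured compounds named here, the change sits on the same ring nitrogen as the one measured step, but benzyl is a group that no measured compound carries, so that step gives only a weak guide to direction or size. A step of moderate size in either direction would be unsurprising.

Compound 3 is therefore expected to give about 66%, with a likely range of 48% to 84%. This estimate means an expected step of a number 1.2 percentage points higher from compound 2 to compound 3 (within the scatter).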

Compound 3, a percentage reported as inhibition, at one concentration (the size of the read-out at that concentration, not a potency): 19.7%
Compound 3: middle estimate off by 46.3 percentage points, on the high side, outside the stated range (below it).
By their numbers in this assay, from the lowest: compound 3; then compound 2; then compound 1.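

Among the compounds shown here, the ring nitrogen is far more sensitive to its substituent than the single earlier step suggested: placing benzyl there gives a number 45.1 percentage points lower from compound 2 to compound 3 (beyond the scatter) and a number 57.2 percentage points lower from compound 1 to compound 3 (beyond the scatter) in this assay. Among these three compounds, the two aromatic rings containing nitrogen keep much of the effect, whereas benzyl, whose ring is carbon only, leaves compound 3 the weakest. Nothing available explains this large loss.

Benzyl differs from pyrimidin-2-yl in two ways at once, bringing a ring of carbon only and an added carbon atom, and these compounds cannot show which difference matters. A phenyl group on the same nitrogen, or a pyridin-3-ylmethyl group, would help to separate the two.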